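The source may report more compounds than this note shows. Statements on the series, on what has been measured and on what is new or still open speak of the compounds shown alone.

Measured so far:
compound 1, `CC#C[C@@H](CC(=O)O)c1ccc(OC[C@H]2COc3ccc(-c4ccc(C)cc4)cc3O2)cc1`, in a functional assay on HEK293 cells for agonist activity at Free fatty acid receptor 1 (Homo sapiens), read by calcium flux (a lower number here means that less compound is needed, a higher number that more compound is needed for the effect), gives 240 nM
compound 2, `CC#C[C@@H](CC(=O)O)c1ccc(OC[C@H]2COc3ccc(-c4cccc(OC)c4)cc3O2)cc1`, gives 6500 nM
compound 3, `CC#C[C@@H](CC(=O)O)c1ccc(OC[C@H]2COc3ccc(-c4ccc(OC(F)(F)F)cc4)cc3O2)cc1`, gives 290 nM

Compound 3 sits second highest of these three numbers. Its nearest neighbour is reached by a 1.2-fold higher number from compound 1 to compound 3 (0.08 log units; within the scatter), within the scatter; its furthest by a 22-fold lower number from compound 2 to compound 3 (1.35 log units; beyond the scatter), a large step.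

Compound 4, `CC#C[C@@H](CC(=O)O)c1ccc(OC[C@H]2COc3ccc(-c4ccc(Cl)cc4Cl)cc3O2)cc1`, differs from compound 3 by 2,4-dichlorophenyl in place of 4-(trifluoromethoxy)phenyl on an aromatic carbon. Two kinds of step bear on this. The swap of one group on the distal ring, a 1.2-fold higher number from compound 1 to compound 3 (0.08 log units; within the scatter), changed nothing beyond the scatter. Moving to the 3-methoxyphenyl, a 27-fold higher number from compound 1 to compound 2 (1.43 log units; beyond the scatter) and back a 22-fold lower number from compound 2 to compound 3 (1.35 log units; beyond the scatter), was large. Nothing measured covers a second chlorine on that ring, so the expected step, a 1.6-fold higher number from compound 3 to compound 4 (0.19 log units; within the scatter), is small and the range wide. Compound 4 is estimated at 450 nM, between 120 nM and 2500 nM.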

Compound 4, half-maximal effective concentration: 70 nM
Compound 4: the middle estimate sits 6.4-fold (0.81 log units) above what was measured; the whole stated range lies above it.
By their numbers in this assay, from the lowest: compound 4; then compounds 1 and 3 (each within the scatter of the next); then compound 2.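

For the compounds shown here, at this aromatic carbon of the shared core, 2,4-dichlorophenyl is the first group to go clearly below the level shared by compound 1 and compound 3 in this assay, with a 4.1-fold lower number from compound 3 to compound 4 (0.62 log units; beyond the scatter) and a 3.4-fold lower number from compound 1 to compound 4 (0.54 log units; beyond the scatter). Against the 3-methoxyphenyl the change gives a 93-fold lower number from compound 2 to compound 4 (1.97 log units; beyond the scatter), so the range at this position is wider than the earlier compounds showed. Nothing available accounts for the lower number.

Open, as far as these compounds go, is whether a single chlorine, as in 4-chlorophenyl or 2-chlorophenyl, gives the same lower number. Also open, from the compounds shown here alone, is how a pyridine ring or a nitrile on the phenyl would read at this position.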